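Replacing a Methyl by Hydrogen on a Second Core

This account rests on a few compounds, and the source may have more. Where it says the series, first, only, none or still open, it means among the compounds named here.

Measured compounds:
- compound 1, `COc1ccc(C(=O)NNC(=S)Nc2csc(-c3ccccc3)c2)cc1`: 36000 nM
- compound 2, `O=C(NNC(=S)Nc1csc(-c2ccccc2)c1)c1ccc(O)cc1`: 75000 nM
- compound 3, `COc1ccc(-c2nnc(Nc3csc(-c4ccccc4)c3)s2)cc1`: 8000 nM

All three were tested in a functional assay on A549 cells (Homo sapiens) for inhibition, read by colorimetric assay and MTT assay, with a stated time of 72 h; a higher number here means a weaker inhibitor, a lower number a stronger inhibitor. Compound 1 and compound 2 share one core and differ in a single spot: hydrogen in place of methyl on an oxygen on an aromatic ring. That change gave a 2.1-fold higher number from compound 1 to compound 2 (0.32 log units; beyond the scatter), so compound 2 is the weaker of the two.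

Compound 3 is built on a different core; the difference between the two cores is not broken down here. In this assay compound 3 gives the lowest of the three numbers, and its gap to compound 1 and to compound 2 lies beyond the usual scatter.

Compound 4, `Oc1ccc(-c2nnc(Nc3csc(-c4ccccc4)c3)s2)cc1`, is not yet measured. It is obtained from compound 3 by hydrogen in place of methyl on an oxygen on an aromatic ring. The place is described in the same words as for compound 1 and compound 2, so this is the same change made on the core of compound 3. If it behaves as it did from compound 1 to compound 2, compound 4 is expected to show a 2.0-fold higher number from compound 3 to compound 4 (0.30 log units; within the scatter). Going by the values given here, since only one earlier example exists, the range is kept wide. Compound 4 is therefore estimated at 16000 nM, between 7000 nM and 36000 nM.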

Compound 4, half-maximal inhibitory concentration: 15000 nM
Beside the measured number, compound 4's estimate is 1.1-fold (0.03 log units) above it; the measured number falls inside the stated range.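

In this assay, swapping 4-methoxyphenyl for 4-hydroxyphenyl on the second core gave a 1.9-fold higher number from compound 3 to compound 4 (0.27 log units; within the scatter), so this step alone cannot be told apart from the ordinary spread of repeated measurements. Set beside the earlier step, the same change reads alike on both cores: the same change on two cores in this assay, a 2.1-fold higher number (0.32 log units; beyond the scatter) from compound 1 to compound 2 and a 1.9-fold higher number (0.27 log units; within the scatter) from compound 3 to compound 4, 1.1-fold (0.05 log units) apart, within the scatter of two such steps. Going by these compounds alone, this shows that the size of the step carried over between these two cores in this one cell assay, but with only two examples it does not show that it would carry to any further core, and it does not explain why the two steps match.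

Among the compounds shown, only methoxy and hydroxy stand at this place, so it remains open what an amine, a carboxylic acid or a longer chain such as butoxy would do there on either core. Also open, going by these compounds, is whether the step would keep its size on a third core.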